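Adding chloro to compound 2 in a cytotoxicity test

The source may hold more compounds than are shown below. What is called first, only, known or untested is meant among the compounds shown, and "the series" means these compounds.

Compound 1 `CC(=O)c1ccc2[nH]c(-c3ccc(Cl)cc3)nc2c1`: > 100000 nM
Compound 2 `CC(=O)c1ccc2c(c1)nc(-c1ccccc1)n2C1CCCCC1`: > 100000 nM

In an ADME assay on MDBK cells (Bos taurus) for cytotoxicity, read by MTT assay, with a stated time of 96 h (on this read-out higher numbers stand for lower toxicity in this test and lower numbers for higher toxicity in this test), compound 2 gives > 100000 nM, which is a limit of the assay and not a number. Both measured compounds stand at the same point: the limit of > 100000 nM in this assay, at which 2 of the 2 values shown sit. Compound 3 `CC(=O)c1ccc2c(c1)nc(-c1ccc(Cl)cc1)n2C1CCCCC1` has chloro in place of hydrogen on an aromatic carbon, para to a large group, turning phenyl to 4-chlorophenyl: chloro in place of hydrogen on an aromatic carbon. Compound 1 also bears 4-chlorophenyl and gives > 100000 nM, again a limit. The expected change in this assay is a number no higher from compound 2 to compound 3 (the limit leaves the size open), with no step beyond the scatter in either direction. Compound 3 is expected at 100000 nM, with an estimated range of 45000 nM to 200000 nM.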

Compound 3, half-maximal cytotoxic concentration: > 100000 nM
Compound 3: no number, only a limit (the forecaster's own chance of this, stated with the estimate: 65%); the middle value sits exactly at the limit.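

With compound 1, compound 2 and compound 3 all at a limit of the assay and not a number, no step among them can be read: the limit of > 100000 nM in this assay, at which 3 of the 3 values shown sit.

The compounds shown leave open whether chloro or cyclohexyl changes the half-maximal cytotoxic concentration at all.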